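Replacing Trifluoromethyl with Ethoxycarbonyl on a Weak Inhibitor

The compounds below may be only part of what the source reports. "The series", "measured", "known", "first", "only" and "open" are said of these compounds alone.

Compound 1 `O=c1[nH]c2cc(C(F)(F)F)ccc2oc1=O` gives 100000 nM
Compound 2 `Cc1ccc2[nH]c(=O)c(=O)oc2c1` gives 32000 nM

In a functional assay with Rattus norvegicus as the target (a lower number here means a stronger inhibitor, a higher number a weaker inhibitor), compound 1 stands at 100000 nM as the higher of the two numbers, which makes it the weaker inhibitor of the pair. Compound 3 `CCOC(=O)c1ccc2oc(=O)c(=O)[nH]c2c1` has not been measured yet. It has ethoxycarbonyl in place of trifluoromethyl on an aromatic carbon, and the counted difference is ethoxycarbonyl in place of trifluoromethyl on an aromatic carbon for anyone comparing the two structures. Going by the values given here, no measured pair shows what such a swap does, so any forecast is uncertain. Among the compounds with values here, the only guide is that compound 2 at 32000 nM reads lower than compound 1 does. The expected change is modest, estimated as a 2.5-fold lower number from compound 1 to compound 3 (0.40 log units; beyond the scatter) in this assay with a shift toward stronger inhibition. The estimated value for compound 3 is 40000 nM in this assay (expected range 12000 nM to 100000 nM).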

Compound 3, half-maximal inhibitory concentration: 10000 nM
Compound 3: middle estimate off by 4.0-fold (0.60 log units), on the high side, and the stated range ends above it.
By their numbers in this assay, from the lowest: compound 3; then compound 2; then compound 1.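

In this assay, ethoxycarbonyl in place of trifluoromethyl gives a 10-fold lower number from compound 1 to compound 3 (1.00 log units; beyond the scatter), so the group on this aromatic carbon, meta to a fused ring and para to a fused ring, clearly matters for inhibition. Going by these compounds alone, this is the first measured step at this carbon, and it shows that the position accepts a group with more heavy atoms, 2 hydrogen-bond acceptors and a double bond outside the aromatic rings, while the inhibitor becomes stronger rather than weaker. Nothing measured here explains why the number falls.

One pair cannot show which part of ethoxycarbonyl matters, and a carboxylic acid, an amide or a methyl ester on the same carbon would help separate those parts. As far as these compounds go, how a longer chain on that ester would read also remains open.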